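Replacing the Methoxyphenyl on the Piperazine of Compound 1

This account rests on a few compounds, and the source may have more. Where it says the series, first, only, none or still open, it means among the compounds named here.

Of the compounds shown here, three sharing a common core have been measured in a functional assay on A-375 cells (Homo sapiens) for antiproliferative activity, read by CCK-8 assay, with a stated time of 72 h, tested at 8 uM; a lower number here means a weaker effect, a higher number a stronger effect of the compound at the concentration tested. Compound 1 `COc1ccc(N2CCN(C(=S)SCc3ccc(C(=O)Nc4ccccc4N)cc3)CC2)cc1` gives 35.9% and stands lowest of the three. Compound 2 `Nc1ccccc1NC(=O)c1ccc(CSC(=S)N2CCc3cc(Cl)ccc32)cc1` gives 82.3%, and compound 3 `CCN(Cc1ccncc1)C(=S)SCc1ccc(C(=O)Nc2ccccc2N)cc1` gives 86.2%; the difference between these two, a number 3.9 percentage points higher from compound 2 to compound 3 (within the scatter), is within the scatter. Compound 1 lies far below both, and its gap to compound 2 and to compound 3 is beyond the scatter.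

Compound 4 `Nc1ccccc1NC(=O)c1ccc(CSC(=S)N2CCN(Cc3cccnc3)CC2)cc1` has not yet been measured. It differs from compound 1 by (pyridin-3-yl)methyl in place of 4-methoxyphenyl on an amine nitrogen in a ring. For the measured compounds named here, no measured step touches this position; the only measured step, a number 3.9 percentage points higher from compound 2 to compound 3 (within the scatter), concerns the group on the thiocarbonyl carbon and offers no direct guide. What the data do show is that the two compounds without the 4-methoxyphenyl substituent both give high inhibition, while compound 1 with it gives the lowest value. The step of a number 26.1 percentage points higher from compound 1 to compound 4 (beyond the scatter) is therefore expected to be upward, though its size is uncertain. Compound 4 is estimated to give 62% in this assay, between 38% and 84%.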

Compound 4, a percentage reported as inhibition, at one concentration (the size of the read-out at that concentration, not a potency): 89.2%
Compound 4: the middle estimate sits 27.2 percentage points below what was measured; the whole stated range lies below it.
By their numbers in this assay, from the lowest: compound 1; then compounds 2, 3 and 4 (each within the scatter of the next).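

The substituent on the amine nitrogen in the six-membered non-aromatic ring with 2 nitrogen strongly affects the read-out in this assay, as shown by the large step of a number 53.3 percentage points higher from compound 1 to compound 4 (beyond the scatter), which lies beyond the scatter. For the compounds shown here, this is the first measured change at this position, and it shows that 4-methoxyphenyl can be replaced there without loss of inhibition at the concentration tested. The swap changes the aromatic ring, its link to the nitrogen and the methoxy group together, and nothing available explains the rise.

The compounds shown leave open which of these changes carries the step, a question that benzyl or phenyl on the same nitrogen would help to separate. They also leave open how a longer chain, such as 2-(pyridin-3-yl)ethyl, would fare at this position.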